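Cyclohexyl for Piperazinone: Estimating Compound 4

This account rests on a few compounds, and the source may have more. Where it says the series, first, only, none or still open, it means among the compounds named here.

Measured compounds:
compound 1, `CC(C)CNC(=O)n1c(=O)oc2cc(C3CCN(C)CC3)ccc21`; in an assay on HEK293 cells for inhibition of acid ceramidase (Homo sapiens), read by fluorescence, with stated times of 10 min and 3 h (on this read-out higher numbers stand for weaker inhibition and lower numbers for stronger inhibition), compound 1 gives 166 nM
compound 2, `CN1CCN(c2ccc3c(c2)oc(=O)n3C(=O)NCCCCc2ccccc2)CC1=O`; compound 2 gives 92 nM
compound 3, `O=C(NCCCCc1ccccc1)n1c(=O)oc2cnccc21`; compound 3 gives 3 nM

Compound 2 stands second highest of the three numbers. Its nearest neighbour is compound 1, whose value lies within the usual scatter of that of compound 2, so no order between these two can be read. Compound 3, built on a different core, lies far lower and well beyond the scatter. Compound 4, `O=C(NCCCCc1ccccc1)n1c(=O)oc2cc(C3CCCCC3)ccc21`, differs from compound 2 in one place: cyclohexyl in place of 4-methyl-3-oxopiperazin-1-yl on an aromatic carbon. Going by the values given here, no pair of measured compounds isolates this exchange, so nothing in the numbers speaks directly to it, and the shared core is kept. The expected step is a 1.8-fold lower number from compound 2 to compound 4 (0.26 log units; within the scatter) in this assay, a modest move toward stronger inhibition rather than none, with a wide margin of doubt. Compound 4 is estimated at 50 nM, with a plausible range from 15 nM to 180 nM.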

Compound 4, half-maximal inhibitory concentration: 89 nM
For compound 4 the middle estimate is 1.8-fold (0.25 log units) below the measured one; the measured number falls inside the stated range.
By their numbers in this assay, from the lowest: compound 3; then compounds 4, 2 and 1 (each within the scatter of the next).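

Within this assay the exchange of 4-methyl-3-oxopiperazin-1-yl for cyclohexyl on this aromatic carbon gives a 1.0-fold lower number from compound 2 to compound 4 (0.01 log units; within the scatter) and so no difference between the two groups can be read at this position. The leaving ring has 2 hetero atoms and 2 hydrogen-bond acceptors, while the entering ring is of carbon only and has none, yet this change in the substituent leaves no readable mark on the number for these two compounds. Nothing at hand bears on why the two groups read alike.

The compounds shown leave open how a carboxylic acid, a primary amine or a methoxy group on this aromatic carbon would read. They also leave open whether cyclohexyl and 4-methyl-3-oxopiperazin-1-yl would still read alike with the side chain of compound 1 on the shared core.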